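The compounds below may be only part of what the source reports. "The series", "measured", "known", "first", "only" and "open" are said of these compounds alone.

Compound 1 (`O=C(NCc1ccc(S(=O)(=O)N2CCCCC2)cc1)c1cc2cnccc2o1`) and compound 2 (`O=C(NCc1ccc(S(=O)(=O)N2CCCCC2)cc1)c1ccn2ccnc2c1`) share the same amide side and differ in the group on the carbonyl carbon. In an ADME assay on microsomes from liver (Mus musculus) for metabolic stability, read by LC-MS, with a stated time of 30 min, tested at 1 uM (on this read-out lower numbers stand for a less stable compound and higher numbers for a more stable compound), compound 1 gives 4.6% as its result, a low figure. Compound 2 stands at "not determined" (no result reported) in the same read-out, so it offers no number to start from. Compound 3 (`O=C(NCc1ccc(S(=O)(=O)N2CCCCC2)cc1)c1ccn2cncc2c1`) has the same atoms as compound 2, joined differently, and the change is this: a group of 9 heavy atoms (7 carbon, 2 nitrogen; one five-membered aromatic ring with 2 hetero atoms, one six-membered aromatic ring with 1 hetero atom) in place of a group of 9 heavy atoms (7 carbon, 2 nitrogen; one five-membered aromatic ring with 2 hetero atoms, one six-membered aromatic ring with 1 hetero atom), on a carbonyl carbon on the carbonyl carbon. For the measured compounds named here, no measured step exists to show what such a swap does in this assay and compound 2 cannot anchor one. Going by the values given here, the only guide is compound 1 at 4.6% as a reference, and no step away from it beyond the usual scatter is expected, in either direction. For compound 3 the estimated value is 8% with an expected range from 1% to 22% in this measurement.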

Compound 3, percent of the compound remaining: 1%
Beside the measured number, compound 3's estimate is 7 percentage points above it, and the stated range covers the measured number.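

In this assay, for the compounds shown here, the measured compounds now give a first step at this position on the carbonyl carbon: a number 3.6 percentage points lower from compound 1 to compound 3 (within the scatter). Exchanging the group of compound 1 for that of compound 3, which has a second ring nitrogen where compound 1 has its oxygen, therefore produced no change that this read-out can separate from the scatter, and compound 3 adds a second low figure for the series. No measurement shown here offers an explanation for this result.

As far as these compounds go, the step between compound 2 and compound 3 cannot be read, so what the different joining of the same atoms does remains open. Also open, from the compounds shown here alone, is whether a phenyl group or a longer alkyl chain on the carbonyl carbon would move the read-out beyond the scatter.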